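Fluorine in place of trifluoromethyl on the pendant phenyl

The source may hold more compounds than are shown below. What is called first, only, known or untested is meant among the compounds shown, and "the series" means these compounds.

Compound 3 `CC#CC(CC(=O)O)c1ccc(OCc2ccn3cc(-c4ccc(C(F)(F)F)cc4)nc3c2)cc1` gives 674 nM in an assay on isolated protein for agonist activity at Free fatty acid receptor 1 (Homo sapiens); on this read-out lower numbers stand for an effect already at smaller amounts and higher numbers for an effect only at larger amounts of compound. Among the three measured compounds it stands second highest: compound 2 `CC#CC(CC(=O)O)c1ccc(OCc2ccn3cc(-c4ccccc4C)nc3c2)cc1` gives 459 nM, and compound 1 `CC#CC(CC(=O)O)c1ccc(OCc2ccn3cc(-c4cccc(C)c4)nc3c2)cc1` gives 1510 nM. The gap a 1.5-fold higher number from compound 2 to compound 3 (0.17 log units; within the scatter) is within the scatter, whereas a 2.2-fold lower number from compound 1 to compound 3 (0.35 log units; beyond the scatter) and a 3.3-fold lower number from compound 1 to compound 2 (0.52 log units; beyond the scatter) are modest steps beyond it.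

Compound 4 `CC#CC(CC(=O)O)c1ccc(OCc2ccn3cc(-c4ccccc4F)nc3c2)cc1` differs from compound 3 by 2-fluorophenyl in place of 4-(trifluoromethyl)phenyl on an aromatic carbon. Within the data shown here, two measured steps bear on this change. The step of a 3.3-fold lower number from compound 1 to compound 2 (0.52 log units; beyond the scatter) shows that a methyl moved to the 2-position of the phenyl gave a modest gain, and the step of a 1.5-fold higher number from compound 2 to compound 3 (0.17 log units; within the scatter) shows that the 2-methylphenyl and the 4-(trifluoromethyl)phenyl sit within the scatter of each other. A 2-fluorophenyl therefore is expected to land close to both, so the step of a 1.2-fold lower number from compound 3 to compound 4 (0.09 log units; within the scatter) is expected to stay within the scatter. For compound 4 in this assay the estimate is 550 nM, with a range from 200 nM to 1500 nM.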

Compound 4, half-maximal effective concentration: 705 nM
Estimate against measurement, compound 4: 1.3-fold (0.11 log units) below; measured number inside the range.
By their numbers in this assay, from the lowest: compounds 2, 3 and 4 (each within the scatter of the next); then compound 1.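

In this assay, the phenyl on the aromatic carbon next to the ring nitrogen accepts 2-fluorophenyl in place of 4-(trifluoromethyl)phenyl without a change beyond the scatter (a 1.0-fold higher number from compound 3 to compound 4 (0.02 log units; within the scatter)), even though the entering group has fewer heavy atoms. Fluoro in place of methyl also stays within the scatter (a 1.5-fold higher number from compound 2 to compound 4 (0.19 log units; within the scatter)), while 2-fluorophenyl remains separated from 3-methylphenyl by a modest step (a 2.1-fold lower number from compound 1 to compound 4 (0.33 log units; beyond the scatter)), so among the four compounds only the 3-methylphenyl stands apart. Nothing available here explains why these phenyl groups read so alike.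

Open, going by these compounds, is how an amine, a methoxy or a carboxylic acid on this phenyl would read in this assay. On these data alone, it also remains open whether fluorine elsewhere on the ring would match the 2-fluorophenyl.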